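The compounds below may be only part of what the source reports. "The series", "measured", "known", "first", "only" and "open" are said of these compounds alone.

Working notes on the series. Of the compounds shown here, three sharing one core have been measured, each varied at the same aromatic carbon. In a functional assay on CWR22R cells (Homo sapiens) for antiproliferative activity, read by CCK-8 assay, with a stated time of 6 days (a lower number here means a stronger inhibitor, a higher number a weaker inhibitor), compound 1 `CCN(c1ccc(C#N)c(Cl)c1)c1cc(-c2cccs2)ccc1C` gives 22000 nM. Compound 2 `CCN(c1ccc(C#N)c(Cl)c1)c1cc(-c2ccccc2)ccc1C` reaches only the limit of this assay, recorded as > 30000 nM, a limit and not a number. Compound 3 `CCN(c1ccc(C#N)c(Cl)c1)c1cc(-n2ccnc2)ccc1C` likewise stands at the limit > 30000 nM in this assay, so no number is known for it. The measured steps are an at least 1.3-fold higher number from compound 1 to compound 2 (0.13 log units; that floor lies within the scatter) and an at least 1.3-fold higher number from compound 1 to compound 3 (0.13 log units; that floor lies within the scatter); the step that the two limits leave unreadable from compound 2 to compound 3 cannot be sized because of the limit of > 30000 nM in this assay, at which 2 of the 3 values shown sit.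

Compound 4 `CCN(c1ccc(C#N)c(Cl)c1)c1cc(-n2cnc3ccccc32)ccc1C` is not yet measured. The change from compound 3 is 1H-benzimidazol-1-yl in place of 1H-imidazol-1-yl on an aromatic carbon. For the measured compounds named here, none of the measured steps covers a change of this kind: they concern thiophen-2-yl, phenyl and 1H-imidazol-1-yl only, and the step starting from compound 3 has no readable size at all. With all three measured values at or near the limit, no shown step points away from that region for the 1H-benzimidazol-1-yl compound. Compound 4 is therefore expected near the limit, estimated at 25000 nM, within 8000 nM to 60000 nM. The step this estimate implies, an at least 1.2-fold lower number from compound 3 to compound 4 (0.07 log units; that floor lies within the scatter), is an expectation only, and a limit rather than a number is a real possibility.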

Compound 4, half-maximal inhibitory concentration: 3040 nM
The estimate for compound 4 lay 8.2-fold (0.92 log units) above the measured number, and the stated range ends above it.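

In this assay, this aromatic carbon, para to a methyl group, turns out to respond to the group it carries: 1H-benzimidazol-1-yl in place of 1H-imidazol-1-yl adds one six-membered aromatic ring of carbon only, leaves the counts of hydrogen-bond donors and acceptors unchanged, and gives an at least 9.8-fold lower number from compound 3 to compound 4 (0.99 log units; beyond the scatter). The same group also stands clear of the two other groups, with an at least 9.8-fold lower number from compound 2 to compound 4 (0.99 log units; beyond the scatter) and a 7.2-fold lower number from compound 1 to compound 4 (0.86 log units; beyond the scatter), so compound 4 is the most potent of the four, its steps to all the others being beyond the scatter. Only the step from the thiophen-2-yl compound has a full size, and the other two are floors because of where compound 2 and compound 3 sit: the limit of > 30000 nM in this assay, at which 2 of the 4 values shown sit.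

On these data alone, whether the larger step needs the whole 1H-benzimidazol-1-yl group remains open, since a 1H-indol-1-yl or a naphthalen-1-yl group at this carbon would separate the added ring from the second ring nitrogen. Also open, as far as these compounds go, is how far the added ring tolerates further groups, such as a methoxy group, an amine or a carboxylic acid.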